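From Ester to Carbamate on the Shared Core

The compounds below may be only part of what the source reports. "The series", "measured", "known", "first", "only" and "open" are said of these compounds alone.

Compound 1 `CCCC(=O)OCC1CN(C(=O)c2cc(OC)c(OC)c(OC)c2)CCN1C(=O)c1cc(OC)c(OC)c(OC)c1` is the stronger of the two measured compounds in a functional assay (Oryctolagus cuniculus) for inhibition of platelet-activating factor receptor (Cavia porcellus) (a lower number here means a stronger inhibitor, a higher number a weaker inhibitor), where compound 1 gives 420 nM. Compound 2 `COc1cc(N2CCN(c3cc(OC)c(OC)c(OC)c3)CC2)cc(OC)c1OC` gives 12500 nM in this assay, a gap beyond the usual scatter. Compound 3 `CCCCNC(=O)OCC1CN(C(=O)c2cc(OC)c(OC)c(OC)c2)CCN1C(=O)c1cc(OC)c(OC)c(OC)c1` differs from compound 1 by butylamino in place of propyl on a carbonyl carbon. Going by the values given here, no measured pair isolates this change. Compound 3 is therefore expected to show a step of a 1.1-fold lower number from compound 1 to compound 3 (0.02 log units; within the scatter) that stays within the usual scatter, in no clear direction. Compound 3 is estimated at 400 nM, with a range from 120 nM to 1400 nM.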

Compound 3, half-maximal inhibitory concentration: 240 nM
Compound 3: the middle estimate sits 1.7-fold (0.22 log units) above what was measured; the range from low to high includes it.
By their numbers in this assay, from the lowest: compounds 3 and 1 (each within the scatter of the next); then compound 2.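

In this assay the step at this position is a 1.8-fold lower number from compound 1 to compound 3 (0.24 log units; within the scatter) and so gives no clear difference: butylamino stands in place of propyl on a carbonyl carbon, adding a nitrogen and a hydrogen-bond donor, without moving the number beyond the scatter. The carbamate thus reads level with the ester on the shared core. Nothing at hand explains this result. Still open, as far as these compounds go, is whether a longer chain, a phenyl ring or a carboxylic acid at this place would keep that level, and whether a methyl group in place of the carbamate hydrogen would change it.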